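Aryl Variation and Cytotoxicity in RAW264.7 Cells

This account rests on a few compounds, and the source may have more. Where it says the series, first, only, none or still open, it means among the compounds named here.

Compound 3 `Cc1ccc(C2=Nn3c(Cc4ccc(S(C)(=O)=O)cc4)nnc3SC2)cc1` gives 37.9% in a functional assay on RAW264.7 cells (Mus musculus) for cytotoxicity, read by MTT assay, with a stated time of 48 h, tested at 50 uM (on this read-out higher numbers stand for a stronger effect at the one concentration tested and lower numbers for a weaker effect), the second highest of three numbers: compound 1 `CS(=O)(=O)c1ccc(Cc2nnc3n2N=C(c2ccccc2)CS3)cc1` gives 46.7%, within the scatter of compound 3, while compound 2 `CS(=O)(=O)c1ccc(Cc2nnc3n2N=C(c2ccc(Cl)cc2Cl)CS3)cc1` gives 27.3%. Compound 4 `CS(=O)(=O)c1ccc(Cc2nnc3n2N=C(c2ccc(O)c(C(N)=O)c2)CS3)cc1` carries 3-carbamoyl-4-hydroxyphenyl in place of 4-methylphenyl on a carbon with a double bond to nitrogen. Two measured steps change the same aryl group on that carbon: a number 19.4 percentage points lower from compound 1 to compound 2 (beyond the scatter) and a number 10.6 percentage points higher from compound 2 to compound 3 (beyond the scatter), both modest, while a number 8.8 percentage points lower from compound 1 to compound 3 (within the scatter). Aryl replacement at this position has therefore shifted the read-out only moderately in either direction, and none of the measured groups resembles the entering one. A modest step is expected in this assay, a number 3.9 percentage points lower from compound 3 to compound 4 (within the scatter), with its direction uncertain. Compound 4 is estimated at 34%, between 18% and 50%.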

Compound 4, a percentage reported as activity, at one concentration (the size of the read-out at that concentration, not a potency): 33.1%
Beside the measured number, compound 4's estimate is 0.9 percentage points above it; the range from low to high includes it.
By their numbers in this assay, from the lowest: compounds 2, 4, 3 and 1 (each within the scatter of the next, the first and the last beyond it).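

In this assay, the 3-carbamoyl-4-hydroxyphenyl group shows that this position tolerates a larger aryl group bearing hydrogen-bond donors, with no step beyond the scatter from the 4-methylphenyl of compound 3 (a number 4.8 percentage points lower from compound 3 to compound 4 (within the scatter)) or the 2,4-dichlorophenyl of compound 2 (a number 5.8 percentage points higher from compound 2 to compound 4 (within the scatter)). Only the change from plain phenyl exceeds the scatter (a number 13.6 percentage points lower from compound 1 to compound 4 (beyond the scatter)). No evidence is available to explain these steps. The compounds shown leave open what the hydroxy or the carbamoyl group gives alone, and whether an amine or a carboxylic acid on the phenyl ring would shift the read-out.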